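A few compounds are considered here, and "the series" means these few. Any claim that something is new, unique, unknown or untested is made for them only; others in the source may bear on it.

In a functional assay on HCT-116 cells (Homo sapiens) for inhibition, read by CCK-8 assay, with a stated time of 48 h (a higher number here means a weaker inhibitor, a lower number a stronger inhibitor), compound 3 `COc1ccc(-c2cc3nccc(-c4cc(OC)c(OC)c(OC)c4)n3n2)cc1N` gives 251 nM. Compound 1 `COc1ccc(-c2cc3nccc(-c4cc(OC)c(OC)c(OC)c4)n3n2)cc1`, at 404 nM, cannot be told apart from it, whereas compound 2 `COc1ccc(-c2cc3nccc(-c4cc(OC)c(OC)c(OC)c4)n3n2)cc1F`, at 2840 nM, stands clearly apart from both. All three differ only at a single aromatic carbon, and the open question is what happens at that carbon in compound 4 `COc1ccc(-c2cc3nccc(-c4cc(OC)c(OC)c(OC)c4)n3n2)cc1[N+](=O)[O-]`. This compound has nitro in place of amino on an aromatic carbon, ortho to a methoxy group and meta to a large group: nitro in place of amino on an aromatic carbon.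

Within the data shown here, three measured steps bear on this change. Amino in place of hydrogen gives a 1.6-fold lower number from compound 1 to compound 3 (0.21 log units; within the scatter), which is within the scatter. Fluoro in place of hydrogen gives a 7.0-fold higher number from compound 1 to compound 2 (0.85 log units; beyond the scatter), a modest step beyond the scatter, and amino in place of fluoro gives an 11-fold lower number from compound 2 to compound 3 (1.05 log units; beyond the scatter), a large one. None of them involves nitro, so they offer only a loose guide. Among the measured compounds shown here, the closest precedent is compound 2 at 2840 nM, the only measured compound carrying neither hydrogen nor amino at this carbon. A modest move towards a higher number is therefore expected, and the estimated step is a 4.4-fold higher number from compound 3 to compound 4 (0.64 log units; beyond the scatter). For compound 4 the expected value is 1100 nM, with an estimated range from 300 nM to 4000 nM.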

Compound 4, half-maximal inhibitory concentration: > 10000 nM
Compound 4: only a limit was reported; the forecaster's own chance of this, stated with the estimate: 3%; middle value at least 9.0-fold (0.95 log units) away from the limit.
By their numbers in this assay, from the lowest: compounds 3 and 1 (each within the scatter of the next); then compound 2. At a limit, above all of these: compound 4.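

In this assay, among these compounds, this aromatic carbon, ortho to a methoxy group and meta to a large group, proves less forgiving than the earlier compounds showed. Nitro goes beyond even the poorest substituent measured before it, with an at least 3.5-fold higher number from compound 2 to compound 4 (0.54 log units; beyond the scatter), so compound 2 no longer marks the high end of what a change at this carbon can do. The change is large when measured against both amino, with an at least 39-fold higher number from compound 3 to compound 4 (1.60 log units; beyond the scatter), and hydrogen, with an at least 24-fold higher number from compound 1 to compound 4 (1.39 log units; beyond the scatter), so the two groups that could not be told apart here both differ sharply from nitro. The value for compound 4 is a limit of the assay and not a number, which makes each of these steps a minimum only: the limit of > 10000 nM in this assay, at which 1 of the 4 values shown sits.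

The compounds shown leave open how far compound 4 really lies from the others, and whether the rise belongs to nitro alone or extends to other groups on this carbon. A hydroxyl, a nitrile or an acetamide at the same place would help to settle that second question.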